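One Aromatic Group Swapped on Two Closely Related Cores

A few compounds are considered here, and "the series" means these few. Any claim that something is new, unique, unknown or untested is made for them only; others in the source may bear on it.

Of the compounds shown here, three have been measured so far in a functional assay on NCI-H460 cells (Homo sapiens) for cytotoxicity, read by MTT assay, with a stated time of 72 h; on this read-out higher numbers stand for weaker inhibition and lower numbers for stronger inhibition. Compound 1 `COc1cccc(-c2cc(C(=O)Nc3ccc(Oc4ccnc5cc(OCCCN6CCCCC6)c(OC)cc45)c(F)c3)c3cc(F)ccc3n2)c1` gives 1000 nM in this assay. Compound 2 `COc1cc2c(Oc3ccc(NC(=O)c4cc(-c5ccc(C)cc5)nc5ccc(F)cc45)cc3F)ccnc2cc1OCCCN1CCCCC1` differs from compound 1 by a single change, (4-methylphenyl in place of 3-methoxyphenyl on an aromatic carbon). Compound 2 gives 260 nM; that step was a 3.8-fold lower number from compound 1 to compound 2 (0.59 log units; beyond the scatter). Compound 3 `COc1cccc(-c2cc(C(=O)Nc3ccc(Oc4ccnc5cc(OCCCN6CCC(C)CC6)c(OC)cc45)c(F)c3)c3cc(F)ccc3n2)c1` gives 840 nM, and the step from compound 1 to compound 3 was a 1.2-fold lower number from compound 1 to compound 3 (0.08 log units; within the scatter), so on this read-out compound 1 and compound 3 cannot be told apart.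

Compound 4 `COc1cc2c(Oc3ccc(NC(=O)c4cc(-c5ccc(C)cc5)nc5ccc(F)cc45)cc3F)ccnc2cc1OCCCN1CCC(C)CC1` has not yet been measured. It differs from compound 3 by 4-methylphenyl in place of 3-methoxyphenyl on an aromatic carbon. Among the compounds with values here, this is the same change as the one from compound 1 to compound 2, made this time on the core of compound 3; the two cores differ only by methyl in place of hydrogen on a saturated ring carbon. Since the change occurs only twice among these compounds, the expectation rests on one measured example. Because the earlier step was a 3.8-fold lower number from compound 1 to compound 2 (0.59 log units; beyond the scatter), and because compound 3 stands at 840 nM, the step from compound 3 to compound 4 is expected to be about a 3.8-fold lower number from compound 3 to compound 4 (0.58 log units; beyond the scatter). Compound 4 is therefore estimated to give 220 nM in this assay, expected to fall between 110 nM and 450 nM.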

Compound 4, half-maximal inhibitory concentration: 480 nM
Beside the measured number, compound 4's estimate is 2.2-fold (0.34 log units) below it; measured number above the stated range.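

In this assay, the swap of 3-methoxyphenyl for 4-methylphenyl on the core of compound 3 gives a 1.8-fold lower number from compound 3 to compound 4 (0.24 log units; within the scatter), and this step cannot be told apart from the same swap on the core of compound 1: the same change on two cores in this assay, a 3.8-fold lower number (0.59 log units; beyond the scatter) from compound 1 to compound 2 and a 1.8-fold lower number (0.24 log units; within the scatter) from compound 3 to compound 4, 2.2-fold (0.34 log units) apart, within the scatter of two such steps. Adding the methyl on the saturated ring gives a 1.8-fold higher number from compound 2 to compound 4 (0.27 log units; within the scatter), and this step likewise cannot be told apart from its earlier counterpart: the same change on two cores in this assay, a 1.2-fold lower number (0.08 log units; within the scatter) from compound 1 to compound 3 and a 1.8-fold higher number (0.27 log units; within the scatter) from compound 2 to compound 4, 2.2-fold (0.34 log units) apart, within the scatter of two such steps. The result fits a swap that carries over between these two cores, but it does not prove this, since two examples cannot separate a constant step from a modest dependence on the core, and the swap's step on the core of compound 3 is itself within the scatter.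

The compounds shown leave open whether the swap would carry over to a core with a hydroxyl group or an amine in place of the methyl on the saturated ring. They also leave open how a phenyl group bearing a chlorine atom would compare with the two aromatic groups here.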